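The source may hold more compounds than are shown below. What is called first, only, known or untested is meant among the compounds shown, and "the series" means these compounds.

Working notes on the series. For the measured compounds named here, compound 1 `Cc1ccc2c(c1)c([C@H](C)Nc1ncnc3[nH]cnc13)nn2-c1cccnc1` and compound 2 `C[C@H](Nc1ncnc2[nH]cnc12)c1nn(-c2ccccn2)c2cc(F)ccc12` share one core but differ in more than one place, so no single step joins them. In a functional assay on Hep 3B2 cells (Homo sapiens) for inhibition, read by sulforhodamine B assay, with a stated time of 72 h, tested at 10 uM (on this read-out higher numbers stand for more inhibition at the one concentration tested (going by the name of the read-out) and lower numbers for less inhibition), compound 1 gives 8%, and in this assay compound 2 gives 12%; the two numbers lie within the scatter of each other, and neither shows appreciable inhibition at the concentration tested. Compound 3 `C[C@H](Nc1ncnc2[nH]cnc12)c1nn(-c2ccncc2)c2cc(F)ccc12` carries the change (pyridin-4-yl in place of pyridin-2-yl on an aromatic nitrogen). With both measured numbers this low, no step beyond the scatter is expected, so the estimated step of a number 2 percentage points lower from compound 2 to compound 3 (within the scatter) is small. Compound 3 is therefore expected at 10%, within 0% to 25%.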

Compound 3, a percentage reported as inhibition, at one concentration (the size of the read-out at that concentration, not a potency): 5%
Estimate against measurement, compound 3: 5 percentage points above; the range from low to high includes it.
By their numbers in this assay, from the lowest: compounds 3, 1 and 2 (each within the scatter of the next).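

Pyridin-4-yl in place of pyridin-2-yl on the aromatic nitrogen gives a number 7 percentage points lower from compound 2 to compound 3 (within the scatter) in this assay, the only step in the series that can be read at one place. At this position, the two pyridinyl groups cannot be told apart on this read-out, so moving the ring nitrogen of this group shows no effect here. Nothing available explains or bears further on this result. Open, on these data alone, is whether a different group on this aromatic nitrogen, such as a phenyl ring carrying a carboxylic acid or an amine, would give a step beyond the scatter.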